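This account rests on a few compounds, and the source may have more. Where it says the series, first, only, none or still open, it means among the compounds named here.

Measured compounds:
- compound 1 `Cc1ccc2ncc(S(=O)(=O)c3ccc(C#N)cc3)c(N3CCC(C)CC3)c2c1`: 55%
- compound 2 `CC1CCN(c2c(S(=O)(=O)c3cc(F)cc(F)c3)cnc3ccc(Cl)cc23)CC1`: 93%
- compound 3 `CC1CCN(c2c(S(=O)(=O)c3ccc(F)cc3)cnc3cc(F)ccc23)CC1`: 74.5%

These three were tested in an assay on isolated protein for displacement of a labelled ligand from metabotropic glutamate receptor 5 (Homo sapiens), with a stated time of 60 min, tested at 1 uM; on this read-out lower numbers stand for less inhibition and higher numbers for more inhibition at the one concentration tested (going by the name of the read-out). Among them compound 1 sits lowest; the gap to compound 3 is beyond the usual scatter, and the gap to compound 2 is wider still. Compound 4 `COc1cccc(S(=O)(=O)c2cnc3ccc(C)cc3c2N2CCC(C)CC2)c1` has not been measured. It differs from compound 1 in one place: 3-methoxyphenyl in place of 4-cyanophenyl on a sulfonyl sulfur. Among the compounds with values here, no step between measured compounds isolates this kind of change, so the direction is uncertain; a small rise that may not exceed the scatter is expected, the step from compound 1 to compound 4 being a number 8 percentage points higher from compound 1 to compound 4 (within the scatter). Compound 4 is estimated at 63%, within 35% to 88%.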

Compound 4, a percentage reported as inhibition, at one concentration (the size of the read-out at that concentration, not a potency): 96%
Beside the measured number, compound 4's estimate is 33 percentage points below it; measured number above the stated range.
By their numbers in this assay, from the lowest: compound 1; then compound 3; then compounds 2 and 4 (each within the scatter of the next).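

In this assay, within the data shown here, putting 3-methoxyphenyl in place of 4-cyanophenyl on a sulfonyl sulfur gives a number 41 percentage points higher from compound 1 to compound 4 (beyond the scatter), the only single-place comparison available here. This shows that the read-out responds strongly to the group at this place, even though both groups have the same counts of heavy atoms and hydrogen-bond acceptors. Nothing available explains the size or direction of this step. From the compounds shown here alone, whether the step follows the arrival of the methoxy group or the loss of the nitrile stays open. An unsubstituted phenyl at this place could help separate the two.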